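Phenyl in Place of Methyl on an Aromatic Nitrogen

This account rests on a few compounds, and the source may have more. Where it says the series, first, only, none or still open, it means among the compounds named here.

compound 1 `O=C(Nc1cnn(-c2ccccc2)c1)c1cccc(NS(=O)(=O)c2ccccc2)c1`: 10100 nM
compound 2 `Cn1cc(NC(=O)c2ccc(NS(=O)(=O)c3ccccc3)cc2)cn1`: > 100000 nM

Both were tested in a functional assay on HepG2 cells (Homo sapiens) for inhibition, read by MTT assay, with a stated time of 48 h; on this read-out higher numbers stand for weaker inhibition and lower numbers for stronger inhibition. Compound 1 gives 10100 nM. For compound 2 the assay reports only a limit, > 100000 nM, so compound 2 stands at the limit of > 100000 nM in this assay, at which 1 of the 2 values shown sits. Compound 3 `O=C(Nc1cnn(-c2ccccc2)c1)c1ccc(NS(=O)(=O)c2ccccc2)cc1` is not yet measured; it differs from compound 2 by phenyl in place of methyl on an aromatic nitrogen. Within the data shown here, no measured step shows this change directly, so only an expectation is possible: a gain beyond the scatter seems plausible, given that compound 1, which also carries the phenyl, gives 10100 nM. Compound 3 is expected near 30000 nM, between 8000 nM and 150000 nM, an estimated step of an at least 3.3-fold lower number from compound 2 to compound 3 (0.52 log units; beyond the scatter).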

Compound 3, half-maximal inhibitory concentration: 21500 nM
Estimate against measurement, compound 3: 1.4-fold (0.14 log units) above, and the stated range covers the measured number.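

In this assay, among these compounds, phenyl in place of methyl on the aromatic nitrogen gives an at least 4.6-fold lower number from compound 2 to compound 3 (0.66 log units; beyond the scatter), the first direct reading of this change, and it shows that this nitrogen's substituent can shift the read-out beyond the scatter. The step has only a minimum size, as the value for compound 2 is a limit and not a number: the limit of > 100000 nM in this assay, at which 1 of the 3 values shown sits.

On these data alone, whether an ethyl or a benzyl group on this nitrogen would give a similar step stays open. So does the effect of an amine or a carboxylic acid on the phenyl ring.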